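Carbamate to Urea on a Biphenyl Amine Core

The source may hold more compounds than are shown below. What is called first, only, known or untested is meant among the compounds shown, and "the series" means these compounds.

Measured compounds:
compound 1 `CCOC(=O)Nc1cccc(-c2ccc(N(C)C)cc2)c1`: 3000 nM
compound 2 `CC(C)OC(=O)Nc1cccc(-c2ccc(N(C)C)cc2)c1`: 82000 nM

In an assay on COS-7 cells for inhibition of patatin-like phospholipase domain-containing protein 2 (Mus musculus) (a lower number here means a stronger inhibitor, a higher number a weaker inhibitor), compound 2 gives the highest of the two numbers, with compound 1 as its nearest neighbour at 3000 nM. Compound 3 `CN(C)C(=O)N(C)c1cccc(-c2ccc(N(C)C)cc2)c1` differs from compound 2 by (dimethylcarbamoyl)(methyl)amino in place of (isopropoxycarbonyl)amino on an aromatic carbon. Going by the values given here, the only measured step, a 27-fold higher number from compound 1 to compound 2 (1.44 log units; beyond the scatter), concerns the alkyl part of the carbamate and does not bear on the exchange of the whole group, so the direction of the change is uncertain. Compound 3 is expected near compound 2, with a 1.4-fold lower number from compound 2 to compound 3 (0.14 log units; within the scatter), at an estimated 60000 nM within 10000 nM to 300000 nM.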

Compound 3, half-maximal inhibitory concentration: 70000 nM
Estimate against measurement, compound 3: 1.2-fold (0.07 log units) below; measured number inside the range.
By their numbers in this assay, from the lowest: compound 1; then compounds 3 and 2 (each within the scatter of the next).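

In this assay the record shows a 1.2-fold lower number from compound 2 to compound 3 (0.07 log units; within the scatter) when (dimethylcarbamoyl)(methyl)amino replaces (isopropoxycarbonyl)amino on the aromatic carbon, so exchanging the whole group, including the loss of the hydrogen-bond donor counted on the group that leaves, does not move the number beyond the scatter. Set against (ethoxycarbonyl)amino, the same entering group gives a 23-fold higher number from compound 1 to compound 3 (1.37 log units; beyond the scatter) and compound 1 stays apart from both other compounds. No supporting data explain these steps.

The compounds shown leave open whether (methoxycarbonyl)amino would give a lower number than compound 1. They also leave open how a urea that keeps the hydrogen on its aryl-bound nitrogen would compare with compound 3.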